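The source may report more compounds than this note shows. Statements on the series, on what has been measured and on what is new or still open speak of the compounds shown alone.

Of the compounds shown here, two have so far been measured in a functional assay on A549 cells (Homo sapiens) for cytotoxicity, read by sulforhodamine B assay, with a stated time of 48 h; a higher number here means a weaker inhibitor of growth, a lower number a stronger inhibitor of growth. Compound 1 `ClCc1ccccc1Cn1cnc2c(Cl)nc(Cl)nc21` gives 4670 nM. Compound 2 `ClCc1cccc(Cn2cnc3c(Cl)ncnc32)c1` gives 39800 nM, the highest of the two numbers, with compound 1 below it by a gap beyond the scatter. Compound 3 `ClCc1cccc(Cn2cnc3c(Cl)nc(Cl)nc32)c1` differs from compound 2 by chloro in place of hydrogen on an aromatic carbon. For the measured compounds named here, no measured pair shows this change alone, yet a move toward a lower number is expected, because compound 1, whose core also carries that chloro group, gives 4670 nM; the expected step is a 4.4-fold lower number from compound 2 to compound 3 (0.65 log units; beyond the scatter). Compound 3 is estimated at 9000 nM, in a range from 2500 nM to 30000 nM.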

Compound 3, concentration for total growth inhibition: 10000 nM
For compound 3 the middle estimate is 1.1-fold (0.05 log units) below the measured one, and the stated range covers the measured number.
By their numbers in this assay, from the lowest: compound 1; then compound 3; then compound 2.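

In this assay, for the compounds shown here, chloro in place of hydrogen on the aromatic carbon between two ring nitrogen atoms gives a 4.0-fold lower number from compound 2 to compound 3 (0.60 log units; beyond the scatter) as the first direct reading of this change alone. At this position, then, chloro goes with stronger inhibition of growth than hydrogen, by a step beyond the usual scatter, though this rests on one pair. No measurement here explains the shift. Going by these compounds, whether an amine or a methoxy group at this position would move the number the same way remains open.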